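The compounds below may be only part of what the source reports. "The series", "measured", "known", "first", "only" and "open" are said of these compounds alone.

Compound 1 `CCOC(=O)c1c(-c2ccccc2)c(-c2ccccc2)n(CC[C@@H]2C[C@@H](O)CC(=O)O2)c1C` gives 4000 nM in an assay for inhibition of 3-hydroxy-3-methylglutaryl-coenzyme A reductase (Rattus norvegicus); a higher number here means a weaker inhibitor, a lower number a stronger inhibitor.
Compound 2 `CCOC(=O)c1c(-c2ccccc2)c(-c2ccccc2)n(CC[C@@H]2C[C@@H](O)CC(=O)O2)c1CC` gives 890 nM in this assay.

Among the measured compounds shown here, of these two numbers, compound 2 holds the lower one; its only neighbour is compound 1, and the single measured step, a 4.5-fold lower number from compound 1 to compound 2 (0.65 log units; beyond the scatter), separates them. The change from compound 2 to compound 3 `CCOC(=O)c1c(-c2ccccc2)c(-c2ccccc2)n(CC[C@@H]2C[C@@H](O)CC(=O)O2)c1C(C)C` is methyl in place of hydrogen on a saturated chain carbon bound to an aromatic carbon and a saturated chain carbon; seen one bond further out, it turns the ethyl chain of compound 2 into an isopropyl group. For the measured compounds named here, the only step that bears on this is a 4.5-fold lower number from compound 1 to compound 2 (0.65 log units; beyond the scatter), which added a carbon at the same place and brought a modest drop in the number, beyond the scatter. Adding one more carbon there may carry on in the same direction, but nothing measured tells whether a second carbon gives as much as the first, so a smaller drop is the fairer expectation, and a flat result within the scatter cannot be ruled out. The step of a 2.5-fold lower number from compound 2 to compound 3 (0.41 log units; beyond the scatter) is therefore what is expected. For compound 3 the estimate is 350 nM, with a likely range from 100 nM to 1200 nM.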

Compound 3, half-maximal inhibitory concentration: 170 nM
Compound 3: middle estimate off by 2.1-fold (0.31 log units), on the high side; measured number inside the range.
By their numbers in this assay, from the lowest: compound 3; then compound 2; then compound 1.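

Methyl in place of hydrogen paid off a second time at this position in this assay: the new step (a 5.2-fold lower number from compound 2 to compound 3 (0.72 log units; beyond the scatter)) is comparable in size to the earlier one (a 4.5-fold lower number from compound 1 to compound 2 (0.65 log units; beyond the scatter)), so the effect had not faded by the isopropyl group, as a smaller second drop would have suggested. Two modest steps add up to a large overall change when isopropyl takes the place of methyl on the aromatic carbon (a 24-fold lower number from compound 1 to compound 3 (1.37 log units; beyond the scatter)), and none of the compounds shown goes against this order of methyl, ethyl and isopropyl. Nothing available here explains why the number falls as this group grows.

Going from ethyl to isopropyl also turns a straight chain into a branched one, so the compounds shown leave open whether the branching itself matters or only the larger group, a question that a straight propyl chain would help to settle. They also leave open where the trend ends, as with a tert-butyl group or a cyclohexyl ring, and how an amine or a hydroxyl group at this place would fare.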